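A few compounds are considered here, and "the series" means these few. Any claim that something is new, unique, unknown or untested is made for them only; others in the source may bear on it.

Measured so far:
- compound 1, `O=C(CCCCCCc1ccccc1)c1ncon1`, an assay for inhibition of Fatty-acid amide hydrolase 1 (Rattus norvegicus), at pH 9.0 (on this read-out higher numbers stand for weaker inhibition and lower numbers for stronger inhibition), 7 nM
- compound 2, `O=C(CCCCCCc1ccccc1)c1nncs1`, 1.4 nM
- compound 3, `O=C(CCCCCCc1ccccc1)c1nnc(-c2ccco2)s1`, 7.4 nM

Compound 3 has the highest number of the three. Its value and that of compound 1 lie within the scatter of each other, so no order between them is claimed. Against compound 2 the gap is real: a 5.3-fold higher number from compound 2 to compound 3 (0.72 log units; beyond the scatter). The other known step, a 5.0-fold lower number from compound 1 to compound 2 (0.70 log units; beyond the scatter), concerns the core and not the group at the far end.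

Compound 4, `O=C(CCCCCCc1ccccc1)c1nnc(-c2cccs2)s1`, differs from compound 3 in one place: thiophen-2-yl in place of furan-2-yl on an aromatic carbon. Within the data shown here, no measured pair shows this particular exchange. The step from compound 2 to compound 3 only tells that placing the furan-2-yl group there raised the number; it does not tell how a thiophen-2-yl group in the same place compares with it. The two groups match in atom count, ring size and acceptor count, so the expectation is a step within the scatter, with no direction that can be supported by the data. Compound 4 is therefore expected to give about 7 nM, range 3 nM to 17 nM, which would mean an expected 1.1-fold lower number from compound 3 to compound 4 (0.02 log units; within the scatter).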

Compound 4, inhibition constant: 27 nM
The estimate for compound 4 lay 3.9-fold (0.59 log units) below the measured number; the whole stated range lies below it.
By their numbers in this assay, from the lowest: compound 2; then compounds 1 and 3 (each within the scatter of the next); then compound 4.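

In this assay, furan-2-yl and thiophen-2-yl are not interchangeable on this aromatic carbon, although the two groups match in heavy-atom count, ring size and acceptor count: the exchange gives a 3.6-fold higher number from compound 3 to compound 4 (0.56 log units; beyond the scatter). Among compounds 2, 3 and 4, hydrogen at this place gives the lowest number, and no compound shown goes against this; the cost of a ring here depends on which ring enters, with thiophen-2-yl giving a 19-fold higher number from compound 2 to compound 4 (1.29 log units; beyond the scatter), compared with a 5.3-fold higher number from compound 2 to compound 3 (0.72 log units; beyond the scatter) for furan-2-yl. Nothing available bears on why replacing the ring oxygen with a ring sulfur moves the number.

The compounds shown leave open whether a methyl, an amine or a carboxylic acid on this carbon would stay close to compound 2 at 1.4 nM or would rise as both rings do. As far as these compounds go, it also remains open whether the exchange of furan-2-yl for thiophen-2-yl would run the same way on the core of compound 1, or with a longer chain between the carbonyl and the phenyl ring.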